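The source may report more compounds than this note shows. Statements on the series, on what has been measured and on what is new or still open speak of the compounds shown alone.

Compound 3, `COc1cc2c(Oc3ccc(NC(=O)c4cc(-c5ccc(C(F)(F)F)cc5)ccn4)cc3F)ccnc2cc1OCCCN1CCN(C)CC1`, is the compound from which compound 4 is drawn. In a functional assay on MKN-45 cells (Homo sapiens) for cytotoxicity, read by MTT assay, with a stated time of 72 h (on this read-out lower numbers stand for stronger inhibition and higher numbers for weaker inhibition), compound 3 gives 330 nM. Compound 1, `COc1cc2c(Oc3ccc(NC(=O)c4cc(-c5ccc(C(F)(F)F)cc5)ccn4)cc3F)ccnc2cc1OCCCN1CCCCC1`, gives 870 nM in this assay, and compound 2, `COc1ccc(-c2ccnc(C(=O)Nc3ccc(Oc4ccnc5cc(OCCCN6CCCCC6)c(OC)cc45)c(F)c3)c2)cc1`, gives 570 nM. The core of compound 3 differs from that of compound 1 in one place: 4-methylpiperazin-1-yl in place of piperidin-1-yl on a saturated chain carbon, three bonds along the chain from an oxygen on an aromatic ring. That change made a 2.6-fold lower number from compound 1 to compound 3 (0.42 log units; beyond the scatter).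

The change from compound 1 to compound 2 is methoxy in place of trifluoromethyl on an aromatic carbon, and it made a 1.5-fold lower number from compound 1 to compound 2 (0.18 log units; within the scatter). The same change, at the same place, leads from compound 3 to compound 4, `COc1ccc(-c2ccnc(C(=O)Nc3ccc(Oc4ccnc5cc(OCCCN6CCN(C)CC6)c(OC)cc45)c(F)c3)c2)cc1`: methoxy in place of trifluoromethyl on an aromatic carbon. Since the change made only a small step on the core of compound 1, as a 1.5-fold lower number from compound 1 to compound 2 (0.18 log units; within the scatter) shows, a step of similar size is expected on the core of compound 3, that is, a 1.5-fold lower number from compound 3 to compound 4 (0.18 log units; within the scatter) is estimated. Compound 4 is therefore expected to give about 220 nM in this assay, with a likely range from 110 nM to 450 nM, pending the actual measurement.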

Compound 4, half-maximal inhibitory concentration: 250 nM
For compound 4 the middle estimate is 1.1-fold (0.06 log units) below the measured one; measured number inside the range.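

In this assay, methoxy in place of trifluoromethyl gives a 1.3-fold lower number from compound 3 to compound 4 (0.12 log units; within the scatter), and the step keeps its size from one core to the other: the same change on two cores in this assay, a 1.5-fold lower number (0.18 log units; within the scatter) from compound 1 to compound 2 and a 1.3-fold lower number (0.12 log units; within the scatter) from compound 3 to compound 4, 1.2-fold (0.06 log units) apart, within the scatter of two such steps. The other change, 4-methylpiperazin-1-yl in place of piperidin-1-yl, gives a 2.3-fold lower number from compound 2 to compound 4 (0.36 log units; beyond the scatter) when read on the methoxy compounds, and it also carries over: the same change on two cores in this assay, a 2.6-fold lower number (0.42 log units; beyond the scatter) from compound 1 to compound 3 and a 2.3-fold lower number (0.36 log units; beyond the scatter) from compound 2 to compound 4, 1.2-fold (0.06 log units) apart, within the scatter of two such steps. Across these four compounds the two changes therefore behave as independent of one another, but this does not show that they would on any other core, and with the methoxy step within the scatter on both cores, it does not separate methoxy from trifluoromethyl in this assay.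

The compounds shown leave open whether another group on that aromatic ring, such as a chlorine atom or a nitrile, would carry over in the same way. They also leave open whether the same holds for another amine at the end of the chain, such as morpholine, or for a shorter chain.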